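The compounds below may be only part of what the source reports. "The series", "measured", "known", "first", "only" and "open" are said of these compounds alone.

Three esters sharing one core have been measured so far in an ADME assay on HepG2 2.2.15 cells (Homo sapiens) for cytotoxicity (a lower number here means that less compound is tolerated, a higher number that more compound is tolerated), on this series. Compound 1 `CC(C)C(=O)OCCc1c(-c2ccccc2Cl)c2cc(Cl)ccc2[nH]c1=O` gives 62000 nM in that test, compound 2 `CCCCC(=O)OCCc1c(-c2ccccc2Cl)c2cc(Cl)ccc2[nH]c1=O` gives 200000 nM there, and compound 3 `CC(=O)N1CCC(C(=O)OCCc2c(-c3ccccc3Cl)c3cc(Cl)ccc3[nH]c2=O)CC1` gives 82000 nM there. Compound 3 thus stands within the scatter of compound 1 (a 1.3-fold higher number from compound 1 to compound 3 (0.12 log units; within the scatter)) and clearly lower than compound 2 (a 2.4-fold lower number from compound 2 to compound 3 (0.39 log units; beyond the scatter)). Compound 4 `O=C(COc1ccccc1)OCCc1c(-c2ccccc2Cl)c2cc(Cl)ccc2[nH]c1=O` carries phenoxymethyl in place of 1-acetylpiperidin-4-yl on a carbonyl carbon. Going by the values given here, no measured step makes this exact swap. Among the compounds with values here, the steps that bear on it are the other changes at the same place, and even the largest of them stayed modest (a 3.2-fold higher number from compound 1 to compound 2 (0.51 log units; beyond the scatter)). Neither those steps nor the structural change points in a clear direction, so no step beyond the scatter is expected in this assay here. For compound 4 the expected value is 85000 nM with an estimated range from 35000 nM to 200000 nM as the likely span. That estimate means an expected 1.0-fold higher number from compound 3 to compound 4 (0.02 log units; within the scatter) overall.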

Compound 4, half-maximal cytotoxic concentration: 81000 nM
Compound 4: middle estimate off by 1.0-fold (0.02 log units), on the high side, within the range that was stated.
By their numbers in this assay, from the lowest: compounds 1, 4 and 3 (each within the scatter of the next); then compound 2.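

In this assay, phenoxymethyl on the carbonyl carbon reads the same as 1-acetylpiperidin-4-yl (a 1.0-fold lower number from compound 3 to compound 4 (0.01 log units; within the scatter)) and as isopropyl (a 1.3-fold higher number from compound 1 to compound 4 (0.12 log units; within the scatter)), so an aromatic ring of carbon only, a non-aromatic ring with a nitrogen and a branched group without a ring do not separate here. Going by these compounds alone, compound 2 alone stands apart, and it now does so against all three other esters, including a 2.5-fold lower number from compound 2 to compound 4 (0.39 log units; beyond the scatter), which leaves butyl as the only group among the four that shifts this number beyond the scatter. Nothing offered here explains why butyl differs from the other groups. Going by these compounds, whether a longer straight chain than butyl would raise the number further remains open. So does whether a free amine or a carboxylic acid at this place would stay with compound 1, compound 3 and compound 4.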